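The source may report more compounds than this note shows. Statements on the series, on what has been measured and on what is new or still open speak of the compounds shown alone.

Compound 1 `COc1cc(NC(C)CCCNC(=O)NC(c2ccccc2)c2ccccc2)c2ncccc2c1` gives > 100000 nM in an ADME assay on WI-38 cells (Homo sapiens), read by MTT assay, with a stated time of 72 h (on this read-out lower numbers stand for stronger inhibition and higher numbers for weaker inhibition), which is a limit of the assay rather than a number.
Compound 2 `COc1cc(NC(C)CCCNC(=O)NCc2ccccc2)c2ncccc2c1` gives 35000 nM in this assay.
Compound 3 `COc1cc(NC(C)CCCNC(=O)NC2CCCCC2)c2ncccc2c1` gives > 100000 nM in this assay, again a limit rather than a measured number.

Going by the values given here, compound 2 therefore stands alone in this assay as the one compound with an actual number; the other two values sit at the limit of > 100000 nM in this assay, at which 2 of the 3 values shown sit, so only the direction of their steps is known, not their full size.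

The step to compound 4 `CCN(CC)C(=O)NCCCC(C)Nc1cc(OC)cc2cccnc12` is diethylamino in place of benzylamino on a carbonyl carbon. Among the compounds with values here, two measured steps bear on it, and both leave the benzyl urea of compound 2 as the best point seen. The step of an at least 2.8-fold lower number from compound 1 to compound 2 (0.45 log units; beyond the scatter) shows that removing a second phenyl from the carbon next to the urea nitrogen made the number fall, while the step of an at least 2.8-fold higher number from compound 2 to compound 3 (0.45 log units; beyond the scatter) shows that replacing the benzyl group with cyclohexyl made it rise again. Every departure from benzyl that has been tried thus weakened inhibition, and diethylamino is a further departure, one that also removes the urea hydrogen.

On this basis the number for compound 4 is expected to rise, probably to the assay limit, a step of about a 2.9-fold higher number from compound 2 to compound 4 (0.46 log units; beyond the scatter). Compound 4 is estimated at 100000 nM, somewhere between 40000 nM and 300000 nM.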

Compound 4, half-maximal inhibitory concentration: > 100000 nM
Compound 4: no number, only a limit (the forecaster's own chance of this, stated with the estimate: 60%); the middle value lies on the limit itself.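

Diethylamino in place of benzylamino on a carbonyl carbon gives an at least 2.8-fold higher number from compound 2 to compound 4 (0.45 log units; beyond the scatter) in this assay. This is the first change shown that removes both the aromatic ring and the hydrogen-bond donor of benzylamino, since compound 1 and compound 3 both keep that donor, and the number still rises out of the measurable range. Compound 4 gives > 100000 nM, which is a limit and not a number, so the step shows its direction but not its full size. The step between compound 3 and compound 4 cannot be read, and compound 2 remains the only compound with an actual number, because the others all sit at the same limit: the limit of > 100000 nM in this assay, at which 3 of the 4 values shown sit.

Because compound 4 loses the ring and the donor together, the compounds shown cannot say which loss matters, or whether the change from benzylamino to diethylamino matters in some other way. Ethylamino, which keeps the amide hydrogen but has no ring, and N-methylbenzylamino, which keeps the ring but has no amide hydrogen, would pull these two changes apart.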